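Swapping Chloro for Fluoro in a Fused Heterocycle Series

The compounds below may be only part of what the source reports. "The series", "measured", "known", "first", "only" and "open" are said of these compounds alone.

Compound 1 `CC(c1ccc(-c2ccccc2)c(F)c1)c1nnc2n1N=C(c1ccc(Cl)cc1)CS2` — 3800 nM
Compound 2 `CC(c1ccc(-c2ccccc2)c(F)c1)c1n[nH]c(=S)n1N` — "not active" (no number reported)
Compound 3 `COc1ccc2cc(C(C)c3n[nH]c(=S)n3N)ccc2c1` — 1900 nM

Of the compounds shown here, three have been tested in a functional assay on Hep 3B2 cells (Homo sapiens) for inhibition, read by sulforhodamine B assay, with a stated time of 72 h; a higher number here means a weaker inhibitor, a lower number a stronger inhibitor. Compound 1 gives 3800 nM in this assay, the higher of the two numbers reported. Compound 3, built around a different aromatic part, gives 1900 nM in this assay, and the gap to compound 1 lies within the usual scatter of repeated measurements, so the two cannot be ranked against each other. The fused ring that carries the 4-chlorophenyl group is absent from compound 2, which otherwise shares the left-hand part of compound 1; in this assay compound 2 is reported as "not active" (no number reported).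

Compound 4 `CC(c1ccc(-c2ccccc2)c(F)c1)c1nnc2n1N=C(c1ccc(F)cc1)CS2` has not yet been measured. It differs from compound 1 in one place: fluoro in place of chloro on an aromatic carbon. Within the data shown here, no pair of measured compounds shows what this kind of exchange does here, so nothing in the data can anchor the size of the step. On general grounds the step from compound 1 to compound 4 is expected to be small, at most close to the edge of the scatter, and more likely toward a weaker inhibitor, as a 1.3-fold higher number from compound 1 to compound 4 (0.12 log units; within the scatter). Compound 4 is therefore estimated at 5000 nM in this assay, within a range of 2000 nM to 12000 nM.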

Compound 4, half-maximal inhibitory concentration: 2600 nM
The estimate for compound 4 lay 1.9-fold (0.28 log units) above the measured number; low and high end bracket the measured number.
By their numbers in this assay, from the lowest: compounds 3, 4 and 1 (each within the scatter of the next).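

Among these compounds, compound 1 and compound 4 form the first pair here that differs in one place only, so the effect of a single exchange can now be read directly. In this assay, replacing 4-chlorophenyl with 4-fluorophenyl gives a 1.5-fold lower number from compound 1 to compound 4 (0.16 log units; within the scatter) and this step lies within the scatter, so chloro and fluoro cannot be told apart at this aromatic carbon, para to a large group. The pair therefore shows that this one exchange leaves the number without a measurable change, although no measurement on the two groups themselves bears on this result.

Going by these compounds, with only these two halogens compared at this carbon, it remains open whether a different kind of group there, such as an amine, a methoxy group or a carboxylic acid, would move the number beyond the scatter. On these data alone, it is also open whether a hydrogen at this carbon would give a similar number, and whether a longer chain in place of the whole outer aromatic ring would still inhibit these cells.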